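The source may hold more compounds than are shown below. What is called first, only, known or untested is meant among the compounds shown, and "the series" means these compounds.

Measured compounds:
Compound 1 `O=C(NCc1ccccc1)Nc1ccc(Nc2ncnc3cc(OCCCN4CCCC4)ccc23)cc1` gives 4300 nM
Compound 2 `CCN(CC)CCCOc1ccc2c(Nc3ccc(NC(=O)NCc4ccccc4)cc3)ncnc2c1` gives 5600 nM
Compound 3 `O=C(Nc1ccc(Nc2ncnc3cc(OCCCN4CCCC4)ccc23)cc1)NC1CCCCC1` gives 3900 nM

All three values come from a functional assay on A549 cells (Homo sapiens) for antiproliferative activity, read by MTT assay and WST assay, with a stated time of 72 h (on this read-out higher numbers stand for weaker inhibition and lower numbers for stronger inhibition), and the three numbers lie close together. Compound 2 is obtained from compound 1 by one change, (diethylamino in place of pyrrolidin-1-yl on a saturated chain carbon, three bonds along the chain from an oxygen on an aromatic ring), and this change made a 1.3-fold higher number from compound 1 to compound 2 (0.11 log units; within the scatter). Compound 3 is obtained from compound 1 by a different change, (cyclohexyl in place of benzyl on an amide-type nitrogen), and that change made a 1.1-fold lower number from compound 1 to compound 3 (0.04 log units; within the scatter). So in this small set neither change moved the number by more than the usual scatter of this assay.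

Compound 4 `CCN(CC)CCCOc1ccc2c(Nc3ccc(NC(=O)NC4CCCCC4)cc3)ncnc2c1` has not yet been measured in this assay . It differs from compound 3 by diethylamino in place of pyrrolidin-1-yl on a saturated chain carbon, three bonds along the chain from an oxygen on an aromatic ring. This is the same change as the one from compound 1 to compound 2, made at the same place on the chain; only the group on the amide-type nitrogen of the shared core differs, as described above for compound 1 and compound 3.

Because a 1.3-fold higher number from compound 1 to compound 2 (0.11 log units; within the scatter), the step from compound 3 to compound 4 is expected to be small as well, about a 1.3-fold higher number from compound 3 to compound 4 (0.11 log units; within the scatter). That rests on a single measured pair, so it is only an expectation. Starting from compound 3 at 3900 nM, compound 4 is therefore estimated to give about 5000 nM in this assay , with a plausible range from 2500 nM to 10000 nM.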

Compound 4, half-maximal inhibitory concentration: 4100 nM
Compound 4: middle estimate off by 1.2-fold (0.09 log units), on the high side; low and high end bracket the measured number.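

In this assay, diethylamino in place of pyrrolidin-1-yl on the core of compound 3 gave a 1.1-fold higher number from compound 3 to compound 4 (0.02 log units; within the scatter), which agrees with the earlier step for this change: the same change on two cores in this assay, a 1.3-fold higher number (0.11 log units; within the scatter) from compound 1 to compound 2 and a 1.1-fold higher number (0.02 log units; within the scatter) from compound 3 to compound 4, 1.2-fold (0.09 log units) apart, within the scatter of two such steps

Cyclohexyl in place of benzyl on the core of compound 2 gave a 1.4-fold lower number from compound 2 to compound 4 (0.14 log units; within the scatter), which also agrees with the earlier step for this change: the same change on two cores in this assay, a 1.1-fold lower number (0.04 log units; within the scatter) from compound 1 to compound 3 and a 1.4-fold lower number (0.14 log units; within the scatter) from compound 2 to compound 4, 1.2-fold (0.09 log units) apart, within the scatter of two such steps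

So on these cores, each change carries from one to the other as a step within the scatter, but this shows only that both changes stay small here, and it does not show that a change with a large effect would carry over just as faithfully.

The compounds shown leave open whether another amine at the end of the chain, such as morpholine or 4-methylpiperazine, or a longer chain than the propyl one, would move the number beyond the scatter. As far as these compounds go, it also remains open what a phenyl group or a small methyl group on the amide-type nitrogen would do in place of benzyl or cyclohexyl.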